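Ring Size on the Amino Nitrogen and Maximal Response

A few compounds are considered here, and "the series" means these few. Any claim that something is new, unique, unknown or untested is made for them only; others in the source may bear on it.

Compound 2 `O=P(O)(O)OC1[C@@H](OP(=O)(O)O)C(CO)O[C@@H](O[C@@H]2[C@H](OP(=O)(O)O)C(n3cnc4c(NC5CCCCC5)ncnc43)O[C@@H]2CO)[C@H]1O` has been characterised in a functional assay on the whole organism with Rattus norvegicus as the target; on this read-out higher numbers stand for larger maximal responses and lower numbers for smaller maximal responses. In this assay compound 2 gives 45%. Among the compounds with values here, this is the higher of the two numbers measured so far, but its only neighbour, compound 1 `CNc1ncnc2c1ncn2C1O[C@H](CO)[C@H](O[C@@H]2OC(CO)[C@H](OP(=O)(O)O)C(OP(=O)(O)O)[C@@H]2O)[C@@H]1OP(=O)(O)O`, stands close to it: in this assay compound 1 gives 37%, and the step of a number 8 percentage points higher from compound 1 to compound 2 (within the scatter) lies within the scatter, so the two values cannot be ranked.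

Compound 3 `O=P(O)(O)OC1[C@@H](OP(=O)(O)O)C(CO)O[C@@H](O[C@@H]2[C@H](OP(=O)(O)O)C(n3cnc4c(NC5CCCC5)ncnc43)O[C@@H]2CO)[C@H]1O` has not yet been measured. It differs from compound 2 in one place: cyclopentyl in place of cyclohexyl on a nitrogen on an aromatic ring. Within the data shown here, only one measured step touches this nitrogen on an aromatic ring, the exchange of methyl for cyclohexyl, and that step, a number 8 percentage points higher from compound 1 to compound 2 (within the scatter), did not leave the scatter. Since a far larger change of the group at this place produced no step beyond the scatter, the account expects none for compound 3 either, and the expected change is a number 3 percentage points lower from compound 2 to compound 3 (within the scatter). For compound 3 in this assay the estimate is 42%, with a range from 30% to 55%.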

Compound 3, largest response reached (reported as maximal response), in percent of the reference or control that the assay uses: 35%
For compound 3 the middle estimate is 7 percentage points above the measured one, and the stated range covers the measured number.
By their numbers in this assay, from the lowest: compounds 3, 1 and 2 (each within the scatter of the next).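

In this assay, the nitrogen on an aromatic ring now carries three different groups, methyl, cyclohexyl and cyclopentyl, and none of them can be ranked against another. Exchanging the six-membered ring of carbon only for the five-membered one gives a number 10 percentage points lower from compound 2 to compound 3 (within the scatter), and replacing methyl with cyclopentyl gives a number 2 percentage points lower from compound 1 to compound 3 (within the scatter). Compound 3 thus adds what the earlier pair could not show: a change of ring size at this place, like the exchange of methyl for a ring, gives no step beyond the scatter, and no evidence is available that bears on this result.

From the compounds shown here alone, the three groups compared here all consist of carbon only, so it remains open whether a phenyl ring, a chain ending in an amine or one ending in a carboxylic acid on this nitrogen would give a step beyond the scatter. The three compounds also share the rest of the core, so they say nothing about how a change elsewhere in it would affect the maximal response.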